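The source may hold more compounds than are shown below. What is called first, only, known or untested is meant among the compounds shown, and "the series" means these compounds.

Values in an ADME assay on the whole organism (Rattus norvegicus, strain Sprague-Dawley) for pharmacokinetics, using cassette dosing, at a dose of 0.5 mg/kg by the intravenous route (on this read-out higher numbers stand for fast clearance and lower numbers for slow clearance), for the compounds tested so far
Compound 1 (`O=C(Nc1ccc2[nH]c(=O)oc2c1)C(=O)N1CCN(c2ccccc2)CC1`) gives "not determined" (no result reported)
Compound 2 (`O=C(Nc1ccc2[nH]c(=O)oc2c1)C(=O)N1CCN(c2ccc(F)c(Cl)c2)CC1`) gives 18.3 mL/min/kg
Compound 3 (`O=C(Nc1ccc2[nH]c(=O)oc2c1)C(=O)N1CCN(c2ccc(C(F)(F)F)c(F)c2)CC1`) gives 5.6 mL/min/kg

Of the two numbers available, the lower belongs to compound 3 at 5.6 mL/min/kg and the only other is that of compound 2 at 18.3 mL/min/kg with a gap beyond the usual scatter of this assay between them. Compound 1 offers no number for comparison.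

The next compound is compound 4 (`COc1ccc(N2CCN(C(=O)C(=O)Nc3ccc4[nH]c(=O)oc4c3)CC2)cc1F`). It keeps the shared core and the fluoro group but carries methoxy in place of trifluoromethyl on an aromatic carbon, ortho to a fluoro group and para to a large group (methoxy in place of trifluoromethyl on an aromatic carbon). Among the measured compounds shown here, no two measured compounds differ in one place only, so the data give no direct measure of this step. For the measured compounds named here, the only guide is the spread of the two numbers. Compound 3 sits at the low end of that spread, and compound 2 shows that this series can reach 18.3 mL/min/kg in clearance. A move upward is therefore expected rather than a further fall, though the support for this is thin. An estimated 2.5-fold higher number from compound 3 to compound 4 (0.40 log units; beyond the scatter) is expected, somewhat beyond the scatter. For compound 4 an expected clearance of 14 mL/min/kg is estimated, with 6 mL/min/kg to 30 mL/min/kg as the expected range.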

Compound 4, clearance: 101 mL/min/kg
Compound 4: middle estimate off by 7.2-fold (0.86 log units), on the low side; the measured number lies above the stated range.
By their numbers in this assay, from the lowest: compound 3; then compound 2; then compound 4.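

In this assay, among the compounds shown here, methoxy in place of trifluoromethyl on an aromatic carbon, ortho to a fluoro group and para to a large group, gives an 18-fold higher number from compound 3 to compound 4 (1.26 log units; beyond the scatter) and is the first change confined to this one position. It shows that this single substituent can move clearance by a large margin while the shared core and the fluoro group stay the same. The exchange of 3-chloro-4-fluorophenyl for 3-fluoro-4-methoxyphenyl on the same amine nitrogen in a ring gives a 5.5-fold higher number from compound 2 to compound 4 (0.74 log units; beyond the scatter) and places compound 4 above both other numbers by more than the scatter, though nothing available accounts for either step.

From the compounds shown here alone, it remains open whether a nitrile or a plain methyl on that aromatic carbon would lie nearer compound 3 or compound 4 in this assay or whether a longer ether such as ethoxy would go beyond compound 4. Also open, going by these compounds, is whether the step from trifluoromethyl to methoxy would keep its size with a chloro group in place of the fluoro group.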